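Removing the sulfonylurea N-methyl on rat aorta

The source may report more compounds than this note shows. Statements on the series, on what has been measured and on what is new or still open speak of the compounds shown alone.

Compound 1 `Cc1ccc(S(=O)(=O)N(C)C(=O)NC(C)c2cc(Br)ccc2OCc2ccccc2)cc1` and compound 2 `Cc1ccc(S(=O)(=O)NC(=O)NC(C)c2cc(Br)ccc2OCc2ccccc2)cc1` share one core; compound 3 `COc1ccc(F)cc1C(C)NC(=O)N(C)S(=O)(=O)c1ccccc1` and compound 4 `COc1ccc(F)cc1C(C)NC(=O)NS(=O)(=O)c1ccccc1` share another, and the difference between the two cores is not broken down here. In a functional assay on thoracic aorta (Rattus norvegicus, strain Wistar), with a stated time of 15 min (a higher number here means that more compound is needed for the effect, a lower number that less compound is needed), compound 1 gives 67100 nM, compound 2 gives 138000 nM and compound 3 gives 10000 nM. The change from compound 1 to compound 2 is hydrogen in place of methyl on an amide-type nitrogen, and it made a 2.1-fold higher number from compound 1 to compound 2 (0.31 log units; beyond the scatter). Compound 4 carries the same change relative to compound 3, (hydrogen in place of methyl on an amide-type nitrogen), and is not yet measured in this assay. Going by the values given here, the step of a 2.1-fold higher number from compound 3 to compound 4 (0.32 log units; beyond the scatter) is expected to sit beside the earlier one because a 2.1-fold higher number from compound 1 to compound 2 (0.31 log units; beyond the scatter) is the single measured example of this change, so the core difference adds uncertainty. Compound 4 is therefore estimated at 21000 nM, with a range from 8000 nM to 60000 nM.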

Compound 4, half-maximal effective concentration: > 300000 nM
Compound 4: only a limit was reported (the forecaster's own chance of this, stated with the estimate: 10%); middle value at least 14-fold (1.15 log units) from the limit.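

In this assay, hydrogen in place of methyl on the amide-type nitrogen gives an at least 30-fold higher number from compound 3 to compound 4 (1.47 log units; beyond the scatter), so the size of the step seen on the core of compound 1 did not carry over to the core of compound 3: the same change on two cores in this assay, a 2.1-fold higher number (0.31 log units; beyond the scatter) from compound 1 to compound 2 and an at least 30-fold higher number (1.47 log units; beyond the scatter) from compound 3 to compound 4, at least 14-fold (1.16 log units) apart, beyond the scatter of two such steps

Going by these compounds, the number rises on both cores, but with one pair per core this shared direction is no rule for the series, and the full size of the second step stays unknown. For compound 4 the reading of > 300000 nM is a limit and not a number: the limit of > 300000 nM in this assay, at which 1 of the 4 values shown sits.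

On these data alone, it remains open how an ethyl group or a longer chain on that nitrogen would compare with methyl and hydrogen on each core. The compounds shown also do not separate which difference between the two cores goes with the gap between the steps.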